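The source may report more compounds than this note shows. Statements on the series, on what has been measured and on what is new or still open speak of the compounds shown alone.

The measured compounds:
Compound 1 `N#Cc1ccc(N2CCCc3c(-c4cccnc4)cccc32)cc1C(F)(F)F` gives 12300 nM in a functional assay on CWR22R cells (Homo sapiens) for antiproliferative activity, read by CCK-8 assay, with a stated time of 6 days; on this read-out lower numbers stand for stronger inhibition and higher numbers for weaker inhibition.
Compound 2 `CCN(c1ccc(C#N)c(Cl)c1)c1cc(-c2cn[nH]c2)ccc1C` gives only a limit, > 30000 nM, in this assay.
Compound 3 `N#Cc1ccc(N2CCc3cc(-c4cnc5ccccc5c4)ccc32)cc1C(F)(F)F` has no result reported in this assay: its entry reads "not determined" (no result reported).

Going by the values given here, of the three values shown, compound 2 alone stands at the edge of what the read-out reports: its entry is a limit and not a number, and it is the one value sitting at the limit of > 30000 nM in this assay, at which 1 of the 3 values shown sits. Among the compounds with values here, compound 1 gives a number, and compound 3 gives none, so no step between measured compounds can be drawn here, and nothing in these results points from one structure to another.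

Compound 4 `CCN(c1ccc(C#N)c(Cl)c1)c1cc(-c2ccnn2C)ccc1C` is the compound not yet measured. It differs from compound 2 in one place (1-methyl-1H-pyrazol-5-yl in place of 1H-pyrazol-4-yl on an aromatic carbon). With compound 2 known only as a limit, there is no fixed starting point from which a step could be counted. The expected step of a number no higher from compound 2 to compound 4 (the limit leaves the size open) is therefore none beyond the scatter, with a fair chance that compound 4 again returns only a limit rather than a number. In this assay compound 4 is estimated at 30000 nM, within a range from 8000 nM to 60000 nM.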

Compound 4, half-maximal inhibitory concentration: 4330 nM
The estimate for compound 4 lay 6.9-fold (0.84 log units) above the measured number; the whole stated range lies above it.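

In this assay, replacing 1H-pyrazol-4-yl with 1-methyl-1H-pyrazol-5-yl on this aromatic carbon, which lies meta to a large group and para to a methyl group, gives an at least 6.9-fold lower number from compound 2 to compound 4 (0.84 log units; beyond the scatter). Going by these compounds alone, this shows for the first time that the read-out responds to a single change at this position, and that the swap yields a number where there was previously only a limit. The step can be read only as a minimum, because compound 2 is held at a limit and not at a number: the limit of > 30000 nM in this assay, at which 1 of the 4 values shown sits.

The swap adds a methyl group, moves the point of attachment on the pyrazole and removes the hydrogen-bond donor counted on the leaving group, all at once, so the compounds shown do not tell which of these changes accounts for the step. On these data alone, how 1-methyl-1H-pyrazol-4-yl, which would separate the methyl group from the point of attachment, or a carboxylic acid at the same place would read in this assay also remains open.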